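A few compounds are considered here, and "the series" means these few. Any claim that something is new, unique, unknown or untested is made for them only; others in the source may bear on it.

Three analogues on a shared core have numbers in a functional assay on EKVX cells (Homo sapiens) for inhibition, read by sulforhodamine B assay, with a stated time of 48 h; a higher number here means a weaker inhibitor of growth, a lower number a stronger inhibitor of growth. Compound 1 `COc1cc(C)cc(-c2nn(CC#N)cc2-c2ccc(-c3cccc(C(C)=O)c3)nc2)c1` gives 3980 nM in this assay. Compound 2 `Cc1cc(O)cc(-c2nn(CC#N)cc2-c2ccnc(-c3ccc(Oc4ccccc4)cc3)c2)c1` gives 2160 nM. Compound 3 `COc1cc(C)cc(-c2nn(CC#N)cc2-c2ccnc(-c3ccc(N(C)C)cc3)c2)c1` gives 696 nM, the lowest of the three, with compound 2 and compound 1 both beyond the scatter above it, so compound 3 is the strongest inhibitor of growth measured here. Compound 4 `Cc1cc(O)cc(-c2nn(CC#N)cc2-c2ccnc(-c3ccc(N(C)C)cc3)c2)c1` is not yet measured; relative to compound 3 it carries hydrogen in place of methyl on an oxygen on an aromatic ring. Within the data shown here, no measured pair shows this exact change in isolation, so no computed step is available. The step of a 1.2-fold higher number from compound 3 to compound 4 (0.09 log units; within the scatter) is expected to be small, at most a modest weakening, likely within the scatter. Compound 4 is estimated at 850 nM, in the range 300 nM to 2500 nM.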

Compound 4, concentration for 50% growth inhibition: 3920 nM
Compound 4: middle estimate off by 4.6-fold (0.66 log units), on the low side, outside the stated range (above it).
By their numbers in this assay, from the lowest: compound 3; then compounds 2, 4 and 1 (each within the scatter of the next).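

In this assay, methoxy to hydroxy on the 3-methoxy-5-methylphenyl group gives a 5.6-fold higher number from compound 3 to compound 4 (0.75 log units; beyond the scatter), so with dimethylamino in place, hydrogen does not stand in for methyl on this oxygen. With hydroxy held constant, dimethylamino in place of phenoxy gives a 1.8-fold higher number from compound 2 to compound 4 (0.26 log units; within the scatter), a step within the scatter, so this pair does not separate those two groups. Nothing available accounts for the step from methoxy to hydroxy. Open, from the compounds shown here alone, is whether ethoxy or an amino group at this place would match methoxy. Also open, going by these compounds, is whether the step from methoxy to hydroxy holds with phenoxy on the aromatic carbon.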